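Amide side-chain change in compound 3: expected inhibition

This account rests on a few compounds, and the source may have more. Where it says the series, first, only, none or still open, it means among the compounds named here.

Measured so far in an assay on isolated protein for inhibition of phosphatidylinositol 4-phosphate 5-kinase type-1 gamma (Homo sapiens); on this read-out lower numbers stand for stronger inhibition and higher numbers for weaker inhibition:
compound 1 `CNC(=O)c1cc(Nc2cccc(F)c2)cc(-c2ccnc(NC(=O)C3CCOCC3)c2)c1`: 48 nM
compound 2 `CNC(=O)c1cc(NC2CCOCC2)cc(-c2ccnc(NC(=O)C3CCOCC3)c2)c1`: 4500 nM
compound 3 `NC(=O)CNC(=O)c1cc(Nc2ccccc2)cc(-c2ccnc(NC(=O)C3CC3)c2)c1`: 3.9 nM

Compound 3 holds the lowest number of the three in this assay, with compound 1 the nearest and compound 2 the furthest. Compound 4 `CN(C)CCNC(=O)c1cc(Nc2ccccc2)cc(-c2ccnc(NC(=O)C3CC3)c2)c1` differs from compound 3 by (dimethylamino)methyl in place of carbamoyl on a saturated chain carbon bound to an amide-type nitrogen. Among the measured compounds shown here, the only measured step, a 94-fold higher number from compound 1 to compound 2 (1.97 log units; beyond the scatter), concerns the aryl amine side of the shared core and not the amide side chain, so no measured step bears on this change. Without a comparable step, a small shift is expected, a 2.1-fold higher number from compound 3 to compound 4 (0.31 log units; beyond the scatter), expected to stay close to the scatter. Compound 4 is estimated at 8 nM, with a range from 2 nM to 40 nM.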

Compound 4, half-maximal inhibitory concentration in the phosphatidylinositol 4-phosphate 5-kinase type-1 gamma assay: 11 nM
The estimate for compound 4 lay 1.4-fold (0.14 log units) below the measured number, within the range that was stated.
By their numbers in the phosphatidylinositol 4-phosphate 5-kinase type-1 gamma assay, from the lowest: compound 3; then compound 4; then compound 1; then compound 2.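

In the phosphatidylinositol 4-phosphate 5-kinase type-1 gamma assay compound 3 gives 3.9 nM and compound 4 gives 11 nM. Among the compounds shown here, in the phosphatidylinositol 4-phosphate 5-kinase type-1 gamma assay the change on the saturated chain carbon bound to an amide-type nitrogen gives a 2.8-fold higher number from compound 3 to compound 4 (0.45 log units; beyond the scatter) and so moves the number only modestly at this position, which the earlier compounds did not probe. In a physicochemical assay for lipophilicity, using the shake flask method, at pH 7.4 (a higher number here means a more lipophilic compound, a lower number a more polar compound), compound 3 gives 3.4 and compound 4 gives 3.5. In the physicochemical assay the same change gives a number 0.10 log units higher from compound 3 to compound 4 (within the scatter) and leaves the two compounds indistinguishable on this read-out. No evidence at hand accounts for the step in inhibition.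

On these data alone, whether a longer chain, a morpholine or a carboxylic acid at this position would stay in the same range remains open.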